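Swapping 3-fluorophenyl for 5-fluoropyridin-3-yl in compound 3

The source may report more compounds than this note shows. Statements on the series, on what has been measured and on what is new or still open speak of the compounds shown alone.

Compound 1 `Nc1ccc(S(=O)(=O)N2CCN(c3ncc(C(O)(C(F)(F)F)C(F)(F)F)cc3C#CCO)CC2)cn1`: < 14 mL.min-1.g-1 (a limit, not a number)
Compound 2 `Nc1ccc(S(=O)(=O)N2CCN(c3ncc(C(O)(C(F)(F)F)C(F)(F)F)cc3C#CCCO)CC2)cn1`: < 14 mL.min-1.g-1 (a limit, not a number)
Compound 3 `Nc1ccc(S(=O)(=O)N2CCN(c3ncc(C(O)(C(F)(F)F)C(F)(F)F)cc3-c3cccc(F)c3)CC2)cn1`: 25 mL.min-1.g-1

Among the measured compounds shown here, in an ADME assay (liver) for metabolic stability, with Liver microsome (Homo sapiens) as the target, using microsomes and NADPH, with a stated time of 30 min, tested at 1 uM (a higher number here means faster removal of the compound, a lower number slower removal), compound 3 gives 25 mL.min-1.g-1, the only true number of the three. Compound 4 `Nc1ccc(S(=O)(=O)N2CCN(c3ncc(C(O)(C(F)(F)F)C(F)(F)F)cc3-c3cncc(F)c3)CC2)cn1` has 5-fluoropyridin-3-yl in place of 3-fluorophenyl on an aromatic carbon. Two measured steps reach this place: an at least 1.7-fold higher number from compound 1 to compound 3 (0.25 log units; that floor lies within the scatter) and an at least 1.7-fold higher number from compound 2 to compound 3 (0.25 log units; that floor lies within the scatter). Both swap a chain for the 3-fluorophenyl group, and neither changes an aromatic ring itself, so they give only weak guidance. Compound 4 keeps an aromatic ring there, as compound 3 with 25 mL.min-1.g-1 does, so only a small downward move is expected: a 1.5-fold lower number from compound 3 to compound 4 (0.17 log units; within the scatter). For compound 4 the estimated value is 17 mL.min-1.g-1, with an expected range of 14 mL.min-1.g-1 to 28 mL.min-1.g-1.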

Compound 4, intrinsic clearance in microsomes: 24 mL.min-1.g-1
Estimate against measurement, compound 4: 1.4-fold (0.15 log units) below; the measured number falls inside the stated range.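

In this assay, putting a ring nitrogen into the aromatic group at this position leaves the number unmoved, with a 1.0-fold lower number from compound 3 to compound 4 (0.02 log units; within the scatter). Against the two hydroxy-bearing chains the pyridine gives an at least 1.7-fold higher number from compound 2 to compound 4 (0.23 log units; that floor lies within the scatter) and an at least 1.7-fold higher number from compound 1 to compound 4 (0.23 log units; that floor lies within the scatter), so it is no better separated from them than the 3-fluorophenyl group was. Those two steps remain floors rather than sizes: the limit of < 14 mL.min-1.g-1 in this assay, at which 2 of the 4 values shown sit.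

Open, as far as these compounds go, is whether a pyrimidine ring, a phenyl ring without fluorine or a simple amine at this position would shift the number beyond the scatter.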